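Trimethoxyphenyl rearrangement on a benzimidazole-thiazolidinedione series

A few compounds are considered here, and "the series" means these few. Any claim that something is new, unique, unknown or untested is made for them only; others in the source may bear on it.

Compound 1 `COc1cc(-c2nc3cc(/C=C4\SC(=O)N(CC(=O)N5CCOCC5)C4=O)ccc3[nH]2)cc(OC)c1OC` is the reference point of this set. In an ADME assay on HEK-293T cells (Homo sapiens) for inhibition, read by MTT assay, with a stated time of 48 h (on this read-out lower numbers stand for stronger inhibition and higher numbers for weaker inhibition), compound 1 gives 18800 nM. Compound 2 `COc1cc(OC)c(-c2nc3cc(/C=C4\SC(=O)N(CC(=O)N5CCOCC5)C4=O)ccc3[nH]2)cc1OC` carries the change (2,4,5-trimethoxyphenyl in place of 3,4,5-trimethoxyphenyl on an aromatic carbon); in this assay compound 2 gives 35700 nM, a step of a 1.9-fold higher number from compound 1 to compound 2 (0.28 log units; within the scatter). Compound 3 `COc1cc(-c2nc3cc(/C=C4\SC(=O)N(Cc5cccc(C)c5)C4=O)ccc3[nH]2)cc(OC)c1OC` differs from compound 1 by 3-methylphenyl in place of (morpholin-4-yl)carbonyl on a saturated chain carbon bound to an amide-type nitrogen in a ring; in this assay compound 3 gives 18900 nM, a step of a 1.0-fold higher number from compound 1 to compound 3 (0.00 log units; within the scatter). All three numbers thus lie within the usual scatter of one another, and no ordering among them is supported.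

Compound 4 `COc1cc(OC)c(-c2nc3cc(/C=C4\SC(=O)N(Cc5cccc(C)c5)C4=O)ccc3[nH]2)cc1OC` is not yet measured. It stands to compound 3 as compound 2 stands to compound 1: the change is 2,4,5-trimethoxyphenyl in place of 3,4,5-trimethoxyphenyl on an aromatic carbon, made at a place described in the same words as for the pair of compound 1 and compound 2, so it is the same change, seen here for the second time. The two cores on which it is made differ by 3-methylphenyl in place of (morpholin-4-yl)carbonyl on a saturated chain carbon bound to an amide-type nitrogen in a ring, and that difference left the number essentially unmoved.

Among the compounds with values here, the only precedent for the change is the step from compound 1 to compound 2, which stayed within scatter. Compound 4 is therefore expected to show a step of about a 1.7-fold higher number from compound 3 to compound 4 (0.23 log units; within the scatter) in this assay, because the earlier step was a 1.9-fold higher number from compound 1 to compound 2 (0.28 log units; within the scatter) and the core difference a 1.0-fold higher number from compound 1 to compound 3 (0.00 log units; within the scatter) gave no reason to expect a different response. Compound 4 is estimated at 32000 nM, with a plausible range from 14000 nM to 75000 nM.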

Compound 4, half-maximal inhibitory concentration: 3350 nM
The estimate for compound 4 lay 9.6-fold (0.98 log units) above the measured number, and the stated range ends above it.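

In this assay the 2,4,5-trimethoxyphenyl in place of 3,4,5-trimethoxyphenyl change gives a 5.6-fold lower number from compound 3 to compound 4 (0.75 log units; beyond the scatter), so a change that stayed within scatter on the core of compound 1 does not carry over unaltered to the core of compound 3: the same change on two cores in this assay, a 1.9-fold higher number (0.28 log units; within the scatter) from compound 1 to compound 2 and a 5.6-fold lower number (0.75 log units; beyond the scatter) from compound 3 to compound 4, 11-fold (1.03 log units) apart, beyond the scatter of two such steps

Read along the other edge of the same four compounds, 3-methylphenyl in place of (morpholin-4-yl)carbonyl gives an 11-fold lower number from compound 2 to compound 4 (1.03 log units; beyond the scatter), so the effects of the two changes do not simply add on this read-out, and a step measured on one core is a poor guide to the other: the same change on two cores in this assay, a 1.0-fold higher number (0.00 log units; within the scatter) from compound 1 to compound 3 and an 11-fold lower number (1.03 log units; beyond the scatter) from compound 2 to compound 4, 11-fold (1.03 log units) apart, beyond the scatter of two such steps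

This does not show why the two places depend on each other, and a single set of four compounds gives no rule for any other group at either place.

On these data alone, it remains open whether the lower number of compound 4 needs the methyl group of the 3-methylphenyl, which an unsubstituted phenyl or a 4-methylphenyl on the same saturated chain carbon would test. As far as these compounds go, it is equally open whether the dependence is specific to the 2,4,5-trimethoxyphenyl arrangement or extends to another aryl group, such as a 2,3,4-trimethoxyphenyl or a 2,4-dimethoxyphenyl, at the aromatic carbon between the two ring nitrogen atoms.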